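This account rests on a few compounds, and the source may have more. Where it says the series, first, only, none or still open, it means among the compounds named here.

Compound 2 `Cc1cc(Sc2ccncc2)c(S(C)(=O)=O)cc1C(=O)N=C(N)N` gives 13 nM in a functional assay for inhibition of sodium/hydrogen exchanger (Oryctolagus cuniculus); on this read-out lower numbers stand for stronger inhibition and higher numbers for weaker inhibition. Among the compounds with values here, only one other compound has been measured, compound 1 `Cc1cc(SC(C)C)c(S(C)(=O)=O)cc1C(=O)N=C(N)N`, whose value of 12 nM sits within the usual scatter of that of compound 2, so the two stand level: the step of a 1.1-fold higher number from compound 1 to compound 2 (0.03 log units; within the scatter) is too small to count as a real change.

Compound 3 `Cc1cc(Oc2cccc(Cl)c2)c(S(C)(=O)=O)cc1C(=O)N=C(N)N` is the next compound. It differs from compound 2 in one place: 3-chlorophenoxy in place of (pyridin-4-yl)sulfanyl on an aromatic carbon.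

Within the data shown here, the one measured step bears on this only partly. It showed that exchanging isopropyl for pyridin-4-yl on the sulfur left the number essentially unchanged, a 1.1-fold higher number from compound 1 to compound 2 (0.03 log units; within the scatter), which suggests that this position tolerates groups of different shape. Among the measured compounds shown here, no measured step covers the exchange of the sulfur for an oxygen, nor the move from a pyridine ring to a chlorinated carbon-only ring, so there is no firm basis for predicting a shift in either direction. On that basis no step beyond the scatter is expected in this assay, with the estimated step being a 1.2-fold higher number from compound 2 to compound 3 (0.06 log units; within the scatter). Compound 3 is therefore estimated at 15 nM, within a range from 6 nM to 45 nM.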

Compound 3, half-maximal inhibitory concentration: 21 nM
Beside the measured number, compound 3's estimate is 1.4-fold (0.15 log units) below it, and the stated range covers the measured number.
By their numbers in this assay, from the lowest: compounds 1, 2 and 3 (each within the scatter of the next).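

Compound 3 changes more at this position than the earlier pair did: the sulfur that carries the ring gives way to an oxygen, and the pyridine ring gives way to a carbon-only ring bearing a chlorine. Even so, this assay shows a 1.6-fold higher number from compound 2 to compound 3 (0.21 log units; within the scatter), and against the isopropylsulfanyl group it shows a 1.8-fold higher number from compound 1 to compound 3 (0.24 log units; within the scatter), so the three compounds stand level and this aromatic carbon, ortho to the methylsulfonyl group, accepts 3-chlorophenoxy, (pyridin-4-yl)sulfanyl and isopropylsulfanyl alike in this read-out. No measurement at hand offers a reason for this tolerance.

The compounds shown leave open how the exchange of sulfur for oxygen and the exchange of one ring for the other each act alone, since both arrive together in compound 3, and a plain phenoxy group or a (3-chlorophenyl)sulfanyl group would pull those two changes apart. They also leave open whether the tolerance reaches beyond groups joined through sulfur or oxygen, for example to an amine or a carboxylic acid at this same carbon.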